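The compounds below may be only part of what the source reports. "The series", "measured", "known", "first", "only" and "open" are said of these compounds alone.

Compound 1 `CCn1nc(-c2cccnc2)c2ccccc2c1=O` gives 87% in an assay on isolated protein (Oryctolagus cuniculus) with Thromboxane-A synthase (Homo sapiens) as the target, tested at 1 uM (on this read-out lower numbers stand for less inhibition and higher numbers for more inhibition at the one concentration tested (going by the name of the read-out)), the lowest of the three numbers measured. Compound 2 `CCCCn1nc(-c2cccnc2)c2ccccc2c1=O` gives 91% and compound 3 `CCCCCCCCn1nc(-c2cccnc2)c2ccccc2c1=O` gives 99% in this assay. The measured steps are a number 4 percentage points higher from compound 1 to compound 2 (within the scatter), a number 12 percentage points higher from compound 1 to compound 3 (beyond the scatter) and a number 8 percentage points higher from compound 2 to compound 3 (within the scatter). Compound 4 `C=CCn1nc(-c2cccnc2)c2ccccc2c1=O` differs from compound 1 in one place: vinyl in place of methyl on a saturated chain carbon bound to an aromatic nitrogen. For the measured compounds named here, no measured step puts vinyl in place of methyl; the known steps lengthen the chain at that position, and only the longest extension moved beyond the scatter. A change of this size on the chain is therefore expected to give, at most, a small rise. Compound 4 is estimated at 89%, within 80% to 97%. This estimate corresponds to an expected step of a number 2 percentage points higher from compound 1 to compound 4 (within the scatter).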

Compound 4, a percentage reported as inhibition, at one concentration (the size of the read-out at that concentration, not a potency): 70%
Beside the measured number, compound 4's estimate is 19 percentage points above it; the measured number lies below the stated range.
By their numbers in this assay, from the lowest: compound 4; then compounds 1, 2 and 3 (each within the scatter of the next, the first and the last beyond it).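

Vinyl in place of methyl on a saturated chain carbon bound to an aromatic nitrogen gives a number 17 percentage points lower from compound 1 to compound 4 (beyond the scatter) in this assay, the first step downward beyond the scatter at this position. The allyl compound also stands apart from the saturated chains, with a number 21 percentage points lower from compound 2 to compound 4 (beyond the scatter) and a number 29 percentage points lower from compound 3 to compound 4 (beyond the scatter), so this position responds to a double bond outside aromatic rings, not only to chain length. No evidence bears on why this happens.

Still open, as far as these compounds go, is whether the fall follows the double bond itself or allyl alone, which a propyl chain or a longer chain ending in a double bond would separate. From the compounds shown here alone, an amine or a carboxylic acid at the chain end also remains unexplored here.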